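The source may hold more compounds than are shown below. What is called first, only, known or untested is meant among the compounds shown, and "the series" means these compounds.

Measured compounds:
- compound 1, `COc1ccc(-c2cc(C(=O)/C=C/c3cc(OC)c(OC)c(OC)c3)nc3cc(-c4ccccc4)nn23)cc1OC`: 16700 nM
- compound 2, `COc1ccc(C(=O)/C=C/c2cc(-c3ccc(OC)c(OC)c3)n3nc(-c4ccccc4)cc3n2)cc1`: 13900 nM

Both were tested in a functional assay on MDA-MB-231 cells (Homo sapiens) for antiproliferative activity, read by MTT assay, with a stated time of 24 h; a higher number here means a weaker inhibitor, a lower number a stronger inhibitor. Compound 1 gives 16700 nM in that setting, and compound 2 gives 13900 nM. The nearest neighbour of compound 2 among the measured numbers is compound 1, and the gap between the two sits within the usual scatter of repeated runs, so the two compounds cannot be told apart on these data.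

Compound 3, `COc1ccc(-c2cc(/C=C/C(=O)c3ccc(C)cc3)nc3cc(-c4ccccc4)nn23)cc1OC`, has not been measured. It differs from compound 2 in one place: methyl in place of methoxy on an aromatic carbon. For the measured compounds named here, no step between two measured compounds is available to calibrate this change, so the expectation rests on the change itself and on the weak activity of both measured compounds. Compound 3 is expected to show a step of a 1.1-fold higher number from compound 2 to compound 3 (0.03 log units; within the scatter), that is, no movement beyond the scatter. In this assay compound 3 is estimated at 15000 nM, with a range from 6000 nM to 40000 nM.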

Compound 3, half-maximal inhibitory concentration: 19800 nM
Beside the measured number, compound 3's estimate is 1.3-fold (0.12 log units) below it; the range from low to high includes it.
By their numbers in this assay, from the lowest: compounds 2, 1 and 3 (each within the scatter of the next).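

For the compounds shown here, exchanging 4-methoxyphenyl for 4-methylphenyl gives the first reading of this position: in this assay the change amounts to a 1.4-fold higher number from compound 2 to compound 3 (0.15 log units; within the scatter) and so cannot be told apart from repeat-run variation. The methoxy, with its oxygen and its hydrogen-bond acceptor, can therefore be replaced here by methyl, with one heavy atom and no acceptor, without a readable difference in this series. Nothing available explains this result or shows how the position behaves in any other setting.

The compounds shown leave open whether a group unlike these two, such as an amine, a carboxylic acid or a longer alkoxy chain, would move the number beyond the scatter at this position. They also leave open whether methyl in place of methoxy would read the same on the other aromatic rings of the shared core.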